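A few compounds are considered here, and "the series" means these few. Any claim that something is new, unique, unknown or untested is made for them only; others in the source may bear on it.

Compound 2 `Cc1cc(Nc2cc(-c3ccccc3)[nH]n2)n2nc(SCc3ccc(Cl)cc3)nc2n1` carries a 4-chlorophenyl group on the saturated chain carbon bound to a sulfur. In an ADME assay on GES1 cells (Homo sapiens) for inhibition, read by MTT assay, with a stated time of 72 h (on this read-out lower numbers stand for stronger inhibition and higher numbers for weaker inhibition), compound 2 gives 31800 nM. Compound 1 `Cc1cc(Nc2cc(-c3ccccc3)[nH]n2)n2nc(SCc3csc4ccccc34)nc2n1` gives 29200 nM in this assay, and the step of a 1.1-fold higher number from compound 1 to compound 2 (0.04 log units; within the scatter) keeps the two within the scatter of each other. Compound 3 `Cc1cc(Nc2cc(-c3ccccc3)[nH]n2)n2nc(SCc3cccc(Br)c3)nc2n1` reaches only the limit > 50000 nM in this assay, a limit of the assay rather than a number; the step of an at least 1.5-fold higher number from compound 2 to compound 3 (0.19 log units; that floor lies within the scatter) rests on that limit (the limit of > 50000 nM in this assay, at which 1 of the 3 values shown sits). Compound 4 `CCCCCc1c(C)nc2nc(SCc3ccc(Cl)cc3)nn2c1Nc1cc(-c2ccccc2)[nH]n1` differs from compound 2 by pentyl in place of hydrogen on an aromatic carbon. None of the three measured steps touches this aromatic carbon, so they set no direction for the pentyl. The step of a 1.1-fold lower number from compound 2 to compound 4 (0.06 log units; within the scatter) is therefore expected to stay within the scatter. Compound 4 is estimated at 28000 nM, between 9000 nM and 80000 nM.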

Compound 4, half-maximal inhibitory concentration: > 50000 nM
Compound 4: no number, only a limit; the forecaster's own chance of this, stated with the estimate: 30%; at least 1.7-fold (0.25 log units) between middle value and limit.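

The pentyl group is the only change at this aromatic carbon among the compounds shown, and in this assay compound 4 gives > 50000 nM, which is a limit and not a number. The step is therefore only a floor: an at least 1.5-fold higher number from compound 2 to compound 4 (0.19 log units; that floor lies within the scatter). It shows that pentyl here does not give a lower number than hydrogen, and it adds a second compound at the limit: the limit of > 50000 nM in this assay, at which 2 of the 4 values shown sit.

From the compounds shown here alone, how far compound 4 truly lies from compound 2 stays open. So does the outcome for a shorter chain such as ethyl, or for an amine or a carboxylic acid, on this carbon.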